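Adding an amino group to the phenyl ring of compound 3

This account rests on a few compounds, and the source may have more. Where it says the series, first, only, none or still open, it means among the compounds named here.

Three compounds share one core and were tested in a functional assay on the whole organism with Rattus norvegicus as the target, at a dose of 1 mg/kg by the oral route; on this read-out lower numbers stand for a weaker effect and higher numbers for a stronger effect at the one dose given. Compound 1 `CCCOc1cc(C(=O)Nc2nn[nH]n2)nc(-c2ccc(N)cc2)c1` gives 64%, and compound 2 `Cc1cc(C(=O)Nc2nn[nH]n2)nc(-c2ccc(N)cc2)c1` gives 75%. Within the data shown here, the one measured step between them, a number 11 percentage points higher from compound 1 to compound 2 (beyond the scatter), is the only step in this set. Compound 3 `CCCCc1cc(C(=O)Nc2nn[nH]n2)nc(-c2ccccc2)c1` gives 56%, the lowest of the three numbers; its gap to compound 1 lies within the scatter, while its gap to compound 2 lies beyond it.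

Compound 4 `CCCCc1cc(C(=O)Nc2nn[nH]n2)nc(-c2ccc(N)cc2)c1` differs from compound 3 by amino in place of hydrogen on an aromatic carbon, which, read one bond further out, is phenyl to 4-aminophenyl. Among the measured compounds shown here, no measured step covers this change: the step from compound 1 to compound 2 concerns a different position and a different group, so it does not bear on it. What the numbers show is that compound 1 and compound 2, which both carry the amino group, give higher numbers than compound 3, one within and one beyond the scatter. On that basis the expected step is a number 8 percentage points higher from compound 3 to compound 4 (within the scatter), a modest rise that may stay within the scatter. Compound 4 is therefore estimated at 64%, with a range from 49% to 79%.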

Compound 4, a percentage reported as inhibition, in the whole organism at one dose (the size of the read-out at that dose, not a potency): 81%
For compound 4 the middle estimate is 17 percentage points below the measured one, and the stated range ends below it.
By their numbers in this assay, from the lowest: compounds 3 and 1 (each within the scatter of the next); then compounds 2 and 4 (each within the scatter of the next).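

In this assay, amino in place of hydrogen on the phenyl ring now has a measured step of its own, with the butyl group held constant: a number 25 percentage points higher from compound 3 to compound 4 (beyond the scatter). With the 4-aminophenyl group present, the other substituent on the core gives a mixed picture, with a number 6 percentage points higher from compound 2 to compound 4 (within the scatter) for butyl against methyl, but a number 17 percentage points higher from compound 1 to compound 4 (beyond the scatter) for butyl in place of propoxy. No measurement here explains why the amino group has this effect.

The compounds shown leave open whether a hydroxyl group or a carboxylic acid in place of the amino group would give a similar step. They also leave open whether the amino step keeps its size when methyl or propoxy stands in place of butyl.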